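A few compounds are considered here, and "the series" means these few. Any claim that something is new, unique, unknown or untested is made for them only; others in the source may bear on it.

Measured so far:
Compound 1, `CCCCOc1cccc(Nc2nc3nonc3nc2O)c1`: 2300 nM
Compound 2, `Oc1nc2nonc2nc1Nc1ccc(OCC2CC2)c(C(F)(F)F)c1`: 1800 nM

In an assay on mitochondria from L6 cells (Rattus norvegicus) for activation, with a stated time of 90 min (a lower number here means that less compound is needed, a higher number that more compound is needed for the effect), compound 1 gives 2300 nM, which is the top of the two numbers, yet compound 2 at 1800 nM lies within the scatter of it, so the two cannot be ranked. Compound 3, `CCc1cccc(Nc2nc3nonc3nc2O)c1`, is not yet measured; it differs from compound 1 by ethyl in place of butoxy on an aromatic carbon. Among the measured compounds shown here, no step between measured compounds shows what this change does. A modest rise in the number, beyond the scatter, is expected, a step of a 2.0-fold higher number from compound 1 to compound 3 (0.29 log units; within the scatter). Compound 3 is therefore estimated at 4500 nM in this assay, between 1600 nM and 13000 nM.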

Compound 3, half-maximal effective concentration: 25200 nM
Beside the measured number, compound 3's estimate is 5.6-fold (0.75 log units) below it; measured number outside the range, above it.
By their numbers in this assay, from the lowest: compounds 2 and 1 (each within the scatter of the next); then compound 3.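

In this assay, replacing butoxy with ethyl on this aromatic carbon gives an 11-fold higher number from compound 1 to compound 3 (1.04 log units; beyond the scatter), so the group at this position clearly affects how much compound is needed. The change shortens the chain and removes its oxygen at once, and this single step cannot separate the two. No measurement shown here explains the rise. Butyl, which keeps the chain but lacks the oxygen, would help to separate them. Also open, as far as these compounds go, is how a methoxy group or an amine at this position would compare with butoxy and ethyl.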